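The compounds below may be only part of what the source reports. "The series", "measured", "known", "first", "only" and "open" are said of these compounds alone.

Working notes on the series. In a functional assay on DU-145 cells (Homo sapiens) for cytotoxicity, in the presence of a further agent that is not named here (on this read-out higher numbers stand for weaker inhibition and lower numbers for stronger inhibition), compound 1 `Clc1ccc(-c2cc(-c3cccnc3)nc(-c3ccsc3)c2)o1` gives 21600 nM and compound 2 `Clc1ccc(-c2cc(-c3ccoc3)cc(-c3cccs3)n2)cc1` gives 21100 nM; the two numbers lie within the scatter of each other, so compound 2 cannot be set apart from compound 1 on this assay. Compound 3 `Clc1ccc(-c2cc(-c3ccc(Cl)o3)cc(-c3cccs3)n2)cc1` is not yet measured. It differs from compound 2 in one place: 5-chlorofuran-2-yl in place of furan-3-yl on an aromatic carbon. Among the compounds with values here, no step between measured compounds is known that would bear on this change. With both known values close together and weak, the step from compound 2 to compound 3 is expected to stay within the scatter, at a 1.2-fold lower number from compound 2 to compound 3 (0.07 log units; within the scatter). Compound 3 is estimated at 18000 nM, in the range 8000 nM to 40000 nM.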

Compound 3, half-maximal inhibitory concentration: 19200 nM
The estimate for compound 3 lay 1.1-fold (0.03 log units) below the measured number; the measured number falls inside the stated range.
By their numbers in this assay, from the lowest: compounds 3, 2 and 1 (each within the scatter of the next).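

In this assay, 5-chlorofuran-2-yl in place of furan-3-yl, opposite the ring nitrogen, gives a 1.1-fold lower number from compound 2 to compound 3 (0.04 log units; within the scatter), so compound 3 cannot be told apart from compound 2. Within the data shown here, this is the first step read at this position, and swapping one furan for the other with an added chlorine leaves the read-out within the scatter. No supporting data bear on this result.

The attachment point of the furan and the chlorine differ together here, so their separate contributions stay unresolved. As far as these compounds go, whether an amine or a carboxylic acid at this position would move the number also remains open.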